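Trifluoromethyl in place of tert-butyl: compound 4 awaited

This account rests on a few compounds, and the source may have more. Where it says the series, first, only, none or still open, it means among the compounds named here.

Measured in a functional assay on CEM-SS cells (Homo sapiens) for cytotoxicity; a lower number here means a stronger inhibitor, a higher number a weaker inhibitor:
Compound 1 `Clc1ccc(Cn2c(Br)nc3cc(Cl)c(Cl)cc32)cc1` gives > 100000 nM as a limit
Compound 2 `COc1ccc(Cn2c(Br)nc3cc(Cl)c(Cl)cc32)cc1` gives 60000 nM as a number
Compound 3 `CC(C)(C)c1ccc(Cn2c(Br)nc3cc(Cl)c(Cl)cc32)cc1` gives > 100000 nM as a limit

Compound 3 has no number, only a limit (> 100000 nM). Compound 1 stands at that same limit too (the limit of > 100000 nM in this assay, at which 2 of the 3 values shown sit). Compound 4 `FC(F)(F)c1ccc(Cn2c(Br)nc3cc(Cl)c(Cl)cc32)cc1` is still to be measured in this assay, and it carries trifluoromethyl in place of tert-butyl on an aromatic carbon.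

Among the measured compounds shown here, no measured step makes this exact exchange, but three exchange groups at the same place. Tert-butyl in place of chloro gives a step that the two limits leave unreadable from compound 1 to compound 3, tert-butyl in place of methoxy gives an at least 1.6-fold higher number from compound 2 to compound 3 (0.22 log units; that floor lies within the scatter), and methoxy in place of chloro gives an at least 1.6-fold lower number from compound 1 to compound 2 (0.22 log units; that floor lies within the scatter). None of these reads beyond the scatter, so no clear change is expected from this exchange. The expected step is an at least 1.1-fold lower number from compound 3 to compound 4 (0.04 log units; that floor lies within the scatter), with no direction beyond the scatter. For compound 4 the estimated value is 90000 nM, with an expected range from 40000 nM to 150000 nM, and it may well be reported only as a limit.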

Compound 4, half-maximal inhibitory concentration: > 100000 nM
Compound 4 ended at the assay's limit; the forecaster's own chance of this, stated with the estimate: 60%; middle value at least 1.1-fold (0.04 log units) away from the limit.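

In this assay compound 4 gives a limit and not a number, which makes trifluoromethyl the third group at this position, para to a large group, to stand there: the limit of > 100000 nM in this assay, at which 3 of the 4 values shown sit. Among the compounds shown here, compound 2 remains the only compound with a number, and the one readable new step is an at least 1.6-fold higher number from compound 2 to compound 4 (0.22 log units; that floor lies within the scatter), a floor that does not clear the scatter. The steps to compound 4 from compound 1 and from compound 3 cannot be read, since both ends are limits, so the exchange of tert-butyl for trifluoromethyl shows no readable change.

On these data alone, how far compound 1, compound 3 and compound 4 lie past the limit, and whether they differ from one another, stays open. Also open, as far as these compounds go, is whether an amine or a carboxylic acid on this aromatic carbon would give a number clearly apart from that of compound 2.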